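A few compounds are considered here, and "the series" means these few. Any claim that something is new, unique, unknown or untested is made for them only; others in the source may bear on it.

Compound 2 `O=C1/C(=C\c2c(Cl)cccc2Cl)c2ccccc2N1c1c(Cl)cccc1Cl` was examined in a functional assay on B16-F10 cells (Homo sapiens) for cytotoxicity against B16-F10 (Mus musculus), read by MTT assay, with a stated time of 72 h; on this read-out higher numbers stand for an effect only at larger amounts of compound and lower numbers for an effect already at smaller amounts. In that test compound 2 reaches only the limit of the assay, > 100 ug/mL, and gives no number. Compound 1 `COc1ccc(/C=C2\C(=O)N(c3c(Cl)cccc3Cl)c3ccccc32)cc1OC` likewise stops at the limit, with > 100 ug/mL in this assay. For compound 3 `O=C1/C(=C\c2cc3ccccc3nc2Cl)c2ccccc2N1c1c(Cl)cccc1Cl` the outcome in this assay is "not determined" (no result reported). Compound 2 thus stands together with compound 1 at the limit of > 100 ug/mL in this assay, at which 2 of the 3 values shown sit, and no measured step separates any two of these compounds, so nothing is known about how large a change in this series can be.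

The path to compound 4 `O=C1/C(=C\c2ccc(F)cc2)c2ccccc2N1c1c(Cl)cccc1Cl` runs through one change: 4-fluorophenyl in place of 2,6-dichlorophenyl on a double-bonded chain carbon bound to a double-bonded ring carbon. For the measured compounds named here, with no measured step to lean on, and the two reported results both sitting at the limit, the step is expected to be small, an at least 1.1-fold lower number from compound 2 to compound 4 (0.04 log units; that floor lies within the scatter), and may not go beyond the scatter. Compound 4 is accordingly estimated at 90 ug/mL in this assay, between 30 ug/mL and 300 ug/mL, with a fair chance that only a limit is reported once more.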

Compound 4, concentration for half-maximal effect: 38 ug/mL
Estimate against measurement, compound 4: 2.4-fold (0.37 log units) above, within the range that was stated.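

In this assay, for the compounds shown here, 4-fluorophenyl in place of 2,6-dichlorophenyl on a double-bonded chain carbon bound to a double-bonded ring carbon gives the first step that can be read, an at least 2.6-fold lower number from compound 2 to compound 4 (0.42 log units; beyond the scatter). This shows that a change at this place can move the result beyond the usual scatter, which compound 1 and compound 2 could not show while both rested at a limit. The step remains a floor and not a full size because compound 2 has no number of its own: the limit of > 100 ug/mL in this assay, at which 2 of the 4 values shown sit.

The compounds shown do not separate the loss of the chlorine atoms from the arrival of the fluorine. As far as these compounds go, how an unsubstituted phenyl or a ring bearing an amine would read at this same carbon also remains open.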